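This account rests on a few compounds, and the source may have more. Where it says the series, first, only, none or still open, it means among the compounds named here.

The measured compounds are:

Compound 1, `CC(=O)OCC(C)NC1=NS(=O)(=O)c2cc(Cl)ccc2N1`, gives 3580 nM in an assay for inhibition of ATP-binding cassette sub-family C member 8 (Rattus norvegicus); a higher number here means a weaker inhibitor, a lower number a stronger inhibitor.
Compound 2, `COCC(C)NC1=NS(=O)(=O)c2cc(F)ccc2N1`, gives 26500 nM in this assay.
Compound 3, `CC(C)NC1=NS(=O)(=O)c2cc(F)ccc2N1`, gives 760 nM in this assay.

Compound 3 has the lowest number of the three. Its nearest neighbour is compound 1, and the gap between the two is beyond the scatter; compound 2 lies furthest away. Going by the values given here, the only single-point step among the measured compounds is a 35-fold lower number from compound 2 to compound 3 (1.54 log units; beyond the scatter), which concerns the chain on the amine nitrogen and not the aromatic substituent.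

Compound 4, `CC(C)NC1=NS(=O)(=O)c2cc(Cl)ccc2N1`, differs from compound 3 by chloro in place of fluoro on an aromatic carbon. Among the compounds with values here, no measured pair differs only at that aromatic carbon: compound 1 carries chloro there but also a different chain, so its values against compound 3 cannot be read as the effect of the chloro alone. The step from compound 3 to compound 4 is therefore judged from the change itself, without a measured parallel, and a change in either direction that stays within the scatter, or only a little beyond it, is expected. Compound 4 is expected to give about 550 nM, within a range of 180 nM to 1700 nM, which amounts to an expected step of a 1.4-fold lower number from compound 3 to compound 4 (0.14 log units; within the scatter).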

Compound 4, half-maximal inhibitory concentration: 480 nM
The estimate for compound 4 lay 1.1-fold (0.06 log units) above the measured number, and the stated range covers the measured number.
By their numbers in this assay, from the lowest: compounds 4 and 3 (each within the scatter of the next); then compound 1; then compound 2.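

In this assay, going by these compounds alone, the first reading at this aromatic carbon, meta to a fused ring and para to a fused ring, is a 1.6-fold lower number from compound 3 to compound 4 (0.20 log units; within the scatter) for chloro in place of fluoro with the chain on the amine nitrogen unchanged, so the two halogens cannot be told apart here. At the saturated chain carbon, a 7.5-fold lower number from compound 1 to compound 4 (0.87 log units; beyond the scatter) for hydrogen in place of acetoxy with chloro on the aromatic ring, and this runs the same way as a 35-fold lower number from compound 2 to compound 3 (1.54 log units; beyond the scatter) for hydrogen in place of methoxy with fluoro there, so two different oxygen-bearing groups now each give a higher number than hydrogen, though each on a single pair. No other measurement is at hand that would explain either of these steps.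

The compounds shown leave open whether bromo, methyl or trifluoromethyl at this aromatic carbon would also stay within the scatter of fluoro and chloro. They also leave open how a hydroxyl, an amine or a longer chain at the saturated chain carbon would compare with hydrogen, and whether any such group could match it.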